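Chloro in Place of Fluoro: From Compound 3 to Compound 4

The source may hold more compounds than are shown below. What is called first, only, known or untested is meant among the compounds shown, and "the series" means these compounds.

Within the data shown here, in an ADME assay on microsomes from liver (Canis lupus familiaris) for metabolic stability (a higher number here means that the compound lasts longer, a lower number that the compound disappears faster), no compound yet gives a number. Compound 1 (`FC(F)(F)c1ccc(NCCNc2ncc(-c3ncc[nH]3)c(-c3ccc(Cl)cc3Cl)n2)nc1`) reads > 0.5 h as a limit. Compound 2 (`Nc1nc(NCCNc2ncc(-c3ncc[nH]3)c(-c3ccc(Cl)cc3)n2)ccc1[N+](=O)[O-]`), with its 4-chlorophenyl group, reads > 0.5 h as a limit as well. Compound 3 (`Nc1nc(NCCNc2ncc(-c3ncc[nH]3)c(-c3cc(F)c(F)cc3F)n2)ccc1[N+](=O)[O-]`) reads > 0.5 h as a limit too, so it stands at a bound and not at a measured half-life. The three measured compounds thus rest on the limit of > 0.5 h in this assay, at which 3 of the 3 values shown sit, and cannot be ranked.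

Compound 4 (`Nc1nc(NCCNc2ncc(-c3ncc[nH]3)c(-c3cc(F)c(Cl)cc3F)n2)ccc1[N+](=O)[O-]`) carries 4-chloro-2,5-difluorophenyl in place of 2,4,5-trifluorophenyl, which is chloro in place of fluoro on an aromatic carbon, para to a large group (chloro in place of fluoro on an aromatic carbon). Among the measured compounds shown here, the one measured step that bears on it is a step that the two limits leave unreadable from compound 2 to compound 3 and it runs from 4-chlorophenyl to 2,4,5-trifluorophenyl with both ends at the same limit, so it offers no size to carry over, though it gives no hint of a loss with chloro on that carbon. The expected change is a step that the limit leaves unreadable from compound 3 to compound 4 and is estimated as none beyond the scatter, with neither direction favoured. Compound 4 is expected to report only a limit again, more likely than not. In this assay the estimate for compound 4 is 0.6 h with an expected range from 0.3 h to 1.2 h if a number is reported at all.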

Compound 4, half-life: > 0.5 h
Compound 4 ended at the assay's limit; the forecaster's own chance of this, stated with the estimate: 70%; the middle value is on the limit's open side.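

In this assay compound 4 reads > 0.5 h as a limit. No new step can be read, neither from compound 2 nor from compound 3 to compound 4, and the whole set rests on one bound: the limit of > 0.5 h in this assay, at which 4 of the 4 values shown sit. The compounds shown leave open how long any of them actually lasts and whether chloro in place of fluoro changes that.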